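Fluoro to methoxy swap across two isomeric cores

The source may hold more compounds than are shown below. What is called first, only, known or untested is meant among the compounds shown, and "the series" means these compounds.

Measured in a functional assay on the whole organism for inhibition, with Rattus norvegicus as the target, at a dose of 30 mg/kg (on this read-out lower numbers stand for less inhibition and higher numbers for more inhibition at the one dose given (going by the name of the read-out)), so far:
Compound 1, `Fc1ccc(-c2nc3cccnc3o2)cc1`: 27%
Compound 2, `Fc1ccc(-c2nc3ncccc3o2)cc1`: 28%
Compound 3, `COc1ccc(-c2nc3cccnc3o2)cc1`: 29%

Compound 1 and compound 2 are built from the same atoms joined differently; the difference between the two cores is not broken down here. In this assay compound 1 gives 27% and compound 2 gives 28%, and the two numbers lie within the usual scatter of each other, so no order between them is read. Compound 3 gives 29% in this assay, again within the scatter of both other values.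

For the measured compounds named here, the single counted change among the measured compounds is methoxy in place of fluoro on an aromatic carbon. It produced a number 2 percentage points higher from compound 1 to compound 3 (within the scatter), a step that does not rise above the noise of repeated measurements.

Compound 4, `COc1ccc(-c2nc3ncccc3o2)cc1`, has not been measured. Going by the values given here, it differs from compound 2 by methoxy in place of fluoro on an aromatic carbon, the same change at the same place as the one between compound 1 and compound 3, but carried out on the core of compound 2 instead of the core of compound 1. It occurs twice among the four compounds. Among the compounds with values here, with only one measured instance, the expectation leans on that instance alone. The step from compound 2 to compound 4 is expected to be a number 2 percentage points higher from compound 2 to compound 4 (within the scatter), matching the size of a number 2 percentage points higher from compound 1 to compound 3 (within the scatter) seen on the other core. Compound 4 is therefore estimated to give about 30% in this assay, with a likely range from 20% to 40%.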

Compound 4, a percentage reported as inhibition, in the whole organism at one dose (the size of the read-out at that dose, not a potency): 14%
Beside the measured number, compound 4's estimate is 16 percentage points above it, outside the stated range (below it).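

In this assay, methoxy in place of fluoro on an aromatic carbon gives a number 14 percentage points lower from compound 2 to compound 4 (beyond the scatter), so on the core of compound 2 this change stands clear of the noise of repeated measurements. The same change does not carry over as one fixed step between the two cores: the same change on two cores in this assay, a number 2 percentage points higher (within the scatter) from compound 1 to compound 3 and a number 14 percentage points lower (beyond the scatter) from compound 2 to compound 4, 16 percentage points apart, beyond the scatter of two such steps This shows only that, for these four compounds, the step measured on one core was no guide to the step on the other; with a single pair on each core and a read-out taken at one dose, it does not show why the two cores part, how the two compounds would compare in potency, or how a further core would behave.

Still open, going by these compounds, is whether the fall on the core of compound 2 belongs to methoxy in particular or would also appear with an amine, a carboxylic acid or a longer alkoxy chain on the same aromatic carbon. Equally open, on these data alone, is whether any of these groups would behave alike on both cores, which would show how far the split seen here extends beyond the swap of fluoro for methoxy.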